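Aryl swap on the saturated ring carbon: compound 4

The source may hold more compounds than are shown below. What is called first, only, known or untested is meant among the compounds shown, and "the series" means these compounds.

Results in a functional assay on Ehrlich cells (Mus musculus) for cytotoxicity, tested at 100 ug/mL; a lower number here means a weaker effect, a higher number a stronger effect of the compound at the concentration tested:
compound 1 `COc1ccc(C2C(C#N)=C(N)N(c3cc(OC)c(OC)c(OC)c3)C3=C2C(=O)CC(C)(C)C3)cc1`: 15%
compound 2 `COc1cc(N2C(N)=C(C#N)C(c3ccc(Cl)cc3Cl)C3=C2CC(C)(C)CC3=O)cc(OC)c1OC`: 100%
compound 3 `COc1ccccc1C1C(C#N)=C(N)N(c2cc(OC)c(OC)c(OC)c2)C2=C1C(=O)CC(C)(C)C2`: 100%

Compound 3 is level with compound 2 at the digits shown, the two together the highest of the three numbers; compound 1 sits far beneath, a number 85 percentage points higher from compound 1 to compound 3 (beyond the scatter). Compound 4 `COc1cc(N2C(N)=C(C#N)C(c3ccc(C)o3)C3=C2CC(C)(C)CC3=O)cc(OC)c1OC` is built from compound 3 by one change: 5-methylfuran-2-yl in place of 2-methoxyphenyl on a saturated ring carbon. Among the compounds with values here, the steps that bear on it both alter the aryl on the same saturated ring carbon: a number 85 percentage points higher from compound 1 to compound 3 (beyond the scatter), large, and no change at the digits printed from compound 2 to compound 3 (within the scatter), within the scatter. Within the data shown here, no compound with a furan on that carbon has been measured. Compound 3 already stands at the top of the scale, so a step in this assay can only be flat or downward; a moderate drop is expected, a number 25 percentage points lower from compound 3 to compound 4 (beyond the scatter). Compound 4 is estimated at 75%, between 30% and 100%.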

Compound 4, a percentage reported as activity, at one concentration (the size of the read-out at that concentration, not a potency): 50%
For compound 4 the middle estimate is 25 percentage points above the measured one; low and high end bracket the measured number.
By their numbers in this assay, from the lowest: compound 1; then compound 4; then compounds 2 and 3 (each within the scatter of the next).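

In this assay the 5-methylfuran-2-yl group on the saturated ring carbon lands at a middle level: a number 50 percentage points lower from compound 3 to compound 4 (beyond the scatter) and a number 50 percentage points lower from compound 2 to compound 4 (beyond the scatter) while a number 35 percentage points higher from compound 1 to compound 4 (beyond the scatter) at the same carbon. The read-out at this carbon therefore takes a third level, set apart from both compound 1 and the pair of compound 2 and compound 3. No measurement at hand accounts for these steps.

On these data alone, whether the level follows the furan ring or its methyl stays open. So does what a phenyl carrying an amine or a carboxylic acid would give on this carbon.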